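Swapping Butyl for Isopropyl in an Alkynoate Enol Ether Series

The source may report more compounds than this note shows. Statements on the series, on what has been measured and on what is new or still open speak of the compounds shown alone.

Measured so far:
compound 1 `CCCCC(C#CC(=O)OC)O/C=C/C(=O)OC` — 250 nM
compound 2 `CC1CCC(C(C)C)C(OC(=O)C#CC(O/C=C/C(=O)OC2CC(C)CCC2C(C)C)C(C)C)C1` — > 100000 nM
compound 3 `CCOC(=O)C#CCO/C=C/C(=O)OC` — 2400 nM

In a functional assay on HBL-100 cells (Homo sapiens) for antiproliferative activity, read by sulforhodamine B assay, with a stated time of 48 h (a higher number here means a weaker inhibitor of growth, a lower number a stronger inhibitor of growth), compound 1 gives 250 nM, the lowest of the two numbers reported. Compound 3, which carries no substituent on the chain carbon between the enol ether oxygen and the triple bond and bears an ethyl ester, gives 2400 nM in this assay, a higher number than compound 1 by a margin beyond the usual scatter. Compound 2, with both esters made from the bulky bicyclic-free menthol alcohol, reaches only a limit in this assay: > 100000 nM, a limit of the assay rather than a number (the limit of > 100000 nM in this assay, at which 1 of the 3 values shown sits).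

The next compound, compound 4 `COC(=O)C#CC(O/C=C/C(=O)OC)C(C)C`, differs from compound 1 in a single place: isopropyl in place of butyl on a saturated chain carbon bound to an oxygen on an unsaturated carbon and a triple-bonded carbon. Among the compounds with values here, no measured pair shows this exact change. Since the substituent is kept but shortened and branched, a small step is expected in this assay, if any, and in the direction of a somewhat higher number; compound 4 is estimated at 400 nM with a range from 150 nM to 1200 nM, a step of a 1.6-fold higher number from compound 1 to compound 4 (0.20 log units; within the scatter) from compound 1.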

Compound 4, concentration for 50% growth inhibition: 450 nM
Compound 4: the middle estimate sits 1.1-fold (0.05 log units) below what was measured; the range from low to high includes it.
By their numbers in this assay, from the lowest: compounds 1 and 4 (each within the scatter of the next); then compound 3. At a limit, above all of these: compound 2.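

Within the data shown here, this is the first comparison that changes only one place, the saturated chain carbon bound to an oxygen on an unsaturated carbon and a triple-bonded carbon. In this assay, isopropyl in place of butyl gives a 1.8-fold higher number from compound 1 to compound 4 (0.26 log units; within the scatter), so compound 1 and compound 4 cannot be told apart and this exchange of one alkyl group for the other leaves growth inhibition unchanged within the scatter. Nothing measured here accounts for this outcome or links it to a property of either group.

The compounds shown leave open whether a longer chain, a phenyl ring or an amine at this carbon would keep growth inhibition at this level in this assay. They also leave open what an unsubstituted carbon at this place would give with the methyl esters kept, since compound 3 differs from compound 1 in more than one place.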